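Aryl swap on the hydrazone of a diaryl ether urea

This account rests on a few compounds, and the source may have more. Where it says the series, first, only, none or still open, it means among the compounds named here.

Measured so far:
compound 1 `COc1ccc(OC)c(/C=N/NC(=O)Nc2ccc(Oc3ccnc(-c4nncn4CCN(C)C)c3)c(F)c2)c1`, a functional assay on U-87MG ATCC cells (Homo sapiens) for cytotoxicity, read by MTT assay, with a stated time of 72 h (on this read-out higher numbers stand for weaker inhibition and lower numbers for stronger inhibition), 6400 nM
compound 2 `COc1ccc(/C=N/NC(=O)Nc2ccc(Oc3ccnc(-c4nncn4CCN(C)C)c3)c(F)c2)c(OC)c1OC`, this assay 7650 nM

Compound 2 holds the higher of the two numbers, but the gap to compound 1, a 1.2-fold higher number from compound 1 to compound 2 (0.08 log units; within the scatter), is within the scatter. Compound 3 `CN(C)CCn1cnnc1-c1cc(Oc2ccc(NC(=O)N/N=C/c3ccccc3O[N+](=O)[O-])cc2F)ccn1` differs from compound 2 by 2-(nitrooxy)phenyl in place of 2,3,4-trimethoxyphenyl on a carbon with a double bond to nitrogen. Going by the values given here, only the step from compound 1 to compound 2 bears on this position, and it stayed within the scatter; no step beyond the scatter is therefore expected here, though the entering group is of a different kind, so the range is set wide. The expected step is a 1.1-fold lower number from compound 2 to compound 3 (0.04 log units; within the scatter). For compound 3 the estimate in this assay is 7000 nM, between 2500 nM and 20000 nM.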

Compound 3, half-maximal inhibitory concentration: 7150 nM
For compound 3 the middle estimate is 1.0-fold (0.01 log units) below the measured one, within the range that was stated.
By their numbers in this assay, from the lowest: compounds 1, 3 and 2 (each within the scatter of the next).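

In this assay, 2-(nitrooxy)phenyl, a group of a different kind from 2,3,4-trimethoxyphenyl and 2,5-dimethoxyphenyl, stays within the scatter of both (a 1.1-fold lower number from compound 2 to compound 3 (0.03 log units; within the scatter); a 1.1-fold higher number from compound 1 to compound 3 (0.05 log units; within the scatter)). On a carbon with a double bond to nitrogen, this read-out therefore does not separate these three aryl groups, so the tolerance seen earlier now extends beyond methoxy-substituted rings. No supporting measurement is available to explain this result. Open, on these data alone, is whether an aryl group carrying an amine or a carboxylic acid, or a longer alkyl chain in place of the aryl group, would give a step beyond the scatter.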